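The compounds below may be only part of what the source reports. "The series", "measured", "known", "first", "only" and "open" are said of these compounds alone.

Three compounds share one core, and each has been tested in a functional assay (aorta) with Oryctolagus cuniculus as the target; a lower number here means tighter binding, a higher number weaker binding. Compound 1 `COc1cc(C(C)=O)ccc1OCCCN1CCC(C(c2ccc(F)cc2)c2ccc(F)c(F)c2)CC1` gives 1.26 nM there. Compound 2 `COc1cc(C(C)=O)ccc1OCCCN1CCC(=C(c2ccc(F)cc2)c2ccc(F)cc2)CC1` gives 3.98 nM. Compound 3 `Fc1ccc(OCCCN2CCC(C(c3ccc(F)cc3)c3ccc(F)cc3)CC2)cc1` gives 1.26 nM, which stands level with compound 1 at the digits shown; together these two are the lowest of the three numbers, and compound 2 lies above them by a gap beyond the usual scatter. Compound 4 `Fc1ccc(C(c2ccc(F)cc2)C2CCN(CCCSc3ccccc3)CC2)cc1` has not yet been measured. It differs from compound 3 in one place: phenylsulfanyl in place of 4-fluorophenoxy on a saturated chain carbon, three bonds along the chain from an amine nitrogen in a ring. Within the data shown here, no measured pair shows this same change, so the expectation rests on compound 3 alone. A small weakening is expected, a 2.0-fold higher number from compound 3 to compound 4 (0.30 log units; within the scatter), though it could still fall within the scatter. Compound 4 is estimated at 2.5 nM, with a range from 0.8 nM to 8 nM.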

Compound 4, dissociation constant: 3.16 nM
For compound 4 the middle estimate is 1.3-fold (0.10 log units) below the measured one; the measured number falls inside the stated range.
By their numbers in this assay, from the lowest: compounds 1 and 3 (each within the scatter of the next); then compounds 4 and 2 (each within the scatter of the next).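

In this assay, putting phenylsulfanyl in place of 4-fluorophenoxy gives a 2.5-fold higher number from compound 3 to compound 4 (0.40 log units; beyond the scatter), a modest weakening, which shows that the group at this end of the chain affects the number. This one change swaps oxygen for sulfur and also removes the fluorine, so the step cannot be assigned to either alone. No measurement at hand explains the step.

Still open, from the compounds shown here alone, is how much each of the two differences contributes. A phenoxy or a 4-fluorophenylsulfanyl group on the same chain would separate them.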